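The source may hold more compounds than are shown below. What is called first, only, known or untested is meant among the compounds shown, and "the series" means these compounds.

Series on the shared core, a sulfonyl-bearing bicyclic carboxamide with varied aryl groups on the amide nitrogen. In a functional assay on the whole organism (gastric mucosa) with Rattus norvegicus as the target (on this read-out higher numbers stand for an effect only at larger amounts of compound and lower numbers for an effect already at smaller amounts), compound 1 `CN1C(C(=O)Nc2cccnc2)=C(O)c2sccc2S1(=O)=O` gives 6.3 mg/kg; compound 2 `CN1C(C(=O)Nc2cnccn2)=C(O)c2sccc2S1(=O)=O` gives 1.8 mg/kg, the lowest of the two numbers. Within the data shown here, the only measured step is a 3.5-fold lower number from compound 1 to compound 2 (0.54 log units; beyond the scatter). Compound 3 `CN1C(C(=O)Nc2nccs2)=C(O)c2sccc2S1(=O)=O` carries 1,3-thiazol-2-yl in place of pyrazin-2-yl on an amide-type nitrogen. Among the measured compounds shown here, no measured step covers this exchange; the one step in this assay only shows that swapping one heteroaryl ring for another on the amide-type nitrogen can shift the read-out modestly, direction uncertain. For compound 3 a step of a 1.1-fold higher number from compound 2 to compound 3 (0.05 log units; within the scatter) is expected, giving an estimate of 2 mg/kg with a range from 0.7 mg/kg to 6 mg/kg.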

Compound 3, dose for half-maximal effect: 2.2 mg/kg
Compound 3: middle estimate off by 1.1-fold (0.04 log units), on the low side; measured number inside the range.
By their numbers in this assay, from the lowest: compounds 2 and 3 (each within the scatter of the next); then compound 1.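

In this assay, the place on the amide-type nitrogen also accepts a five-membered ring, as 1,3-thiazol-2-yl and pyrazin-2-yl cannot be told apart (a 1.2-fold higher number from compound 2 to compound 3 (0.09 log units; within the scatter)). The same ring set against pyridin-3-yl gives a 2.9-fold lower number from compound 1 to compound 3 (0.46 log units; beyond the scatter), so compound 1 stands apart from both other compounds whatever the ring size. No measurement at hand offers a reason for this. Still open, on these data alone, is whether plain phenyl or pyridin-2-yl on this nitrogen would group with compound 1 or with the other two compounds. Also open, as far as these compounds go, is what a methyl group on the 1,3-thiazol-2-yl ring would do.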